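A few compounds are considered here, and "the series" means these few. Any claim that something is new, unique, unknown or untested is made for them only; others in the source may bear on it.

Three compounds sharing one core have been measured so far in a functional assay on A-375 cells (Homo sapiens) for activation, with a stated time of 3 days (on this read-out higher numbers stand for an effect only at larger amounts of compound and lower numbers for an effect already at smaller amounts), with these results:

- compound 1 `O=C(Nc1ccc(-c2cscn2)cc1)C1CCCN(Cc2ccc(F)c(F)c2)C1` gives 1240 nM
- compound 2 `O=C(Nc1ccc(-c2cccnc2)cc1)C1CCCN(Cc2ccc(F)c(F)c2)C1` gives 1060 nM
- compound 3 `O=C(Nc1ccc(-c2cc[nH]c2)cc1)C1CCCN(Cc2ccc(F)c(F)c2)C1` gives 2610 nM

Compound 3 has the highest number of the three, so it needs the largest amount of compound to show its effect. Its gaps to the others are modest but beyond the scatter, with a 2.1-fold higher number from compound 1 to compound 3 (0.32 log units; beyond the scatter) on one side and a 2.5-fold higher number from compound 2 to compound 3 (0.39 log units; beyond the scatter) on the other. The remaining pair shows a 1.2-fold lower number from compound 1 to compound 2 (0.07 log units; within the scatter) and so cannot be told apart.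

Compound 4 `O=C(Nc1ccc(-c2ccc[nH]2)cc1)C1CCCN(Cc2ccc(F)c(F)c2)C1` has the same atoms as compound 3, joined differently. The change is 1H-pyrrol-2-yl in place of 1H-pyrrol-3-yl on an aromatic carbon and in short it puts 1H-pyrrol-2-yl in place of 1H-pyrrol-3-yl on an aromatic carbon. Among the compounds with values here, no measured pair shows this kind of shift within a single ring. The nearest evidence is the three swaps of one ring for another at this same place, and these are all small. Compound 1 at 1240 nM and compound 2 at 1060 nM both sit lower than compound 3, so a slight lean downward is expected. The estimated step is a 1.3-fold lower number from compound 3 to compound 4 (0.12 log units; within the scatter) and it is expected to stay within the scatter. For compound 4 the estimated value is 2000 nM with an expected range from 900 nM to 4500 nM in this assay once it is measured.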

Compound 4, half-maximal effective concentration: 720 nM
Beside the measured number, compound 4's estimate is 2.8-fold (0.44 log units) above it, and the stated range ends above it.
By their numbers in this assay, from the lowest: compounds 4, 2 and 1 (each within the scatter of the next); then compound 3.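

In this assay there is a 3.6-fold lower number from compound 3 to compound 4 (0.56 log units; beyond the scatter) even though 1H-pyrrol-3-yl and 1H-pyrrol-2-yl are the same ring with the same atoms, so this position responds to how the ring is joined to the six-membered aromatic ring, and not only to which ring sits there. The other two steps, a 1.5-fold lower number from compound 2 to compound 4 (0.17 log units; within the scatter) and a 1.7-fold lower number from compound 1 to compound 4 (0.24 log units; within the scatter), show that compound 4 cannot be told apart from the pyridin-3-yl and 1,3-thiazol-4-yl compounds, which leaves compound 3 as the only one of the four that stands apart, with the highest number. Nothing measured here explains why the point of attachment makes this difference.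

The compounds shown leave open whether the hydrogen-bond donor counted on both pyrrole groups matters, a question that furan-2-yl or thiophen-2-yl at this place, or 1-methylpyrrol-2-yl, would help to answer. They also leave open whether a ring is needed here at all, since a simple amine or a carboxylic acid in its place would test how much this position tolerates.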